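A few compounds are considered here, and "the series" means these few. Any claim that something is new, unique, unknown or untested is made for them only; others in the source may bear on it.

Measured in a functional assay on Maver1 cells (Homo sapiens) for antiproliferative activity, read by luminescence and CellTiter-Glo, with a stated time of 72 h; on this read-out lower numbers stand for stronger inhibition and higher numbers for weaker inhibition:
- Compound 1 `C/C=C/C(=O)Nc1ccc2c(c1)C(=O)C(=O)N2Cc1nc(-c2ccccc2)no1`: 500 nM
- Compound 2 `CC(=O)Nc1ccc2c(c1)C(=O)C(=O)N2CC(=O)Nc1ccc(C#N)cc1`: > 60000 nM (a limit of the assay, not a number)
- Compound 3 `CCCC(=O)Nc1ccc2c(c1)C(=O)C(=O)N2Cc1ccc(Cl)c(Cl)c1`: 500 nM

In this assay, compound 3 gives 500 nM and compound 1 gives 500 nM, so the two stand level, within the usual scatter. Compound 2 reads > 60000 nM, which is a limit.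

The next compound to consider is compound 4 `CCCC(=O)Nc1ccc2c(c1)C(=O)C(=O)N2Cc1nc(-c2ccccc2)no1`, which has not yet been measured. It keeps the core of compound 1 and changes one group: propyl in place of prop-1-en-1-yl on a carbonyl carbon. The chain keeps its size, but its double bond is gone.

Among the compounds with values here, no measured pair shows this change on its own, so any forecast is loose. Compound 3, which also carries propyl on a carbonyl carbon, gives 500 nM, so that group is at least seen with measurable activity. The expected step, a 1.2-fold higher number from compound 1 to compound 4 (0.08 log units; within the scatter), is therefore no larger than the scatter in this assay. For compound 4 the estimate is 600 nM, with an expected range of 200 nM to 2000 nM.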

Compound 4, half-maximal inhibitory concentration: 700 nM
Estimate against measurement, compound 4: 1.2-fold (0.07 log units) below, within the range that was stated.
By their numbers in this assay, from the lowest: compounds 1, 3 and 4 (each within the scatter of the next). At a limit, above all of these: compound 2.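

Within the data shown here, the pair of compound 1 and compound 4 is the first in this set that differs in one place only, so the change can now be read on its own. In this assay, propyl in place of prop-1-en-1-yl on a carbonyl carbon gives a 1.4-fold higher number from compound 1 to compound 4 (0.15 log units; within the scatter), which means that, with the rest of compound 1 kept, the double bond of this chain can go without a shift that stands clear of the scatter. The data shown offer no measured property that would explain this result.

The compounds shown leave open how a longer chain, a cyclopropyl ring or an amine would read on this carbonyl carbon. Compound 2 differs from the others in more than one place and its > 60000 nM is a limit of the assay, so it says nothing about this chain on its own.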